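A Hydroxy Group Gives Way to Bromo

The source may report more compounds than this note shows. Statements on the series, on what has been measured and on what is new or still open speak of the compounds shown alone.

Of the compounds shown here, three built on one shared core have been measured in a functional assay, read by Griess assay, with a stated time of 2.5 h; on this read-out higher numbers stand for weaker inhibition and lower numbers for stronger inhibition. Compound 1 `COc1ccc(C(=O)/C=C/c2cc(OC)c(OC)cc2OC)cc1` gives 2.07 ug/mL, compound 2 `COc1cc(OC)c(OC)cc1/C=C/C(=O)c1cc(Cl)ccc1O` gives 2.32 ug/mL, and compound 3 `COc1cc(OC)c(OC)cc1/C=C/C(=O)c1ccc(O)cc1` gives 2.5 ug/mL. These three values lie within the scatter of one another, so compound 3 cannot be ranked against the other two.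

Compound 4 `COc1cc(OC)c(OC)cc1/C=C/C(=O)c1ccc(Br)cc1` has not yet been measured. It differs from compound 3 by a single change: bromo in place of hydroxy on an aromatic carbon. In words, this is bromo in place of hydroxy on an aromatic carbon, turning 4-hydroxyphenyl into 4-bromophenyl.

Among the compounds with values here, no measured step makes this exact swap, so the evidence is indirect. Putting hydrogen in place of methyl on the oxygen gave a 1.2-fold higher number from compound 1 to compound 3 (0.08 log units; within the scatter). Exchanging the whole group on the carbonyl carbon gave a 1.1-fold higher number from compound 1 to compound 2 (0.05 log units; within the scatter) and a 1.1-fold higher number from compound 2 to compound 3 (0.03 log units; within the scatter). Within the data shown here, all three steps stay within the scatter, although none of the measured compounds carries bromo, so the range should stay generous.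

No step beyond the scatter is therefore expected, and the estimated step is a 1.0-fold lower number from compound 3 to compound 4 (0.02 log units; within the scatter). For compound 4 the expected value is 2.4 ug/mL, with an estimated range from 1.2 ug/mL to 5 ug/mL.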

Compound 4, half-maximal inhibitory concentration: 2.22 ug/mL
Estimate against measurement, compound 4: 1.1-fold (0.03 log units) above, within the range that was stated.
By their numbers in this assay, from the lowest: compounds 1, 4, 2 and 3 (each within the scatter of the next).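

In this assay, bromo, which counts no hydrogen-bond donor or acceptor, in place of hydroxy, which counts one of each, gives a 1.1-fold lower number from compound 3 to compound 4 (0.05 log units; within the scatter), so at this place, on an aromatic carbon para to a large group, the hydroxy is not needed to keep the number where it stands. The other two comparisons agree: bromo in place of methoxy gives a 1.1-fold higher number from compound 1 to compound 4 (0.03 log units; within the scatter), and 4-bromophenyl in place of 5-chloro-2-hydroxyphenyl gives a 1.0-fold lower number from compound 2 to compound 4 (0.02 log units; within the scatter), so all four groups shown on the carbonyl carbon read alike, and a halogen alone at this place fits in with them. Nothing measured here accounts for this sameness.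

The compounds shown leave open whether the number would stay put with a group of another kind at this place, such as an amine, a carboxylic acid or a longer alkyl chain. They also leave open how much the read-out depends on the rest of the shared core. All four compounds keep it unchanged and only the group on the carbonyl carbon varies.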